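The source may hold more compounds than are shown below. What is called first, only, known or untested is meant among the compounds shown, and "the series" means these compounds.

Compound 1 `O=C(Nc1nccs1)c1cccc(Nc2ncc(F)c(Nc3ccc(F)cc3)n2)c1` carries a (1,3-thiazol-2-yl)carbamoyl group on an aromatic carbon of its shared core. In a functional assay on DU-145 cells (Homo sapiens) for antiproliferative activity, read by sulforhodamine B assay, with a stated time of 3 days (a higher number here means a weaker inhibitor of growth, a lower number a stronger inhibitor of growth), compound 1 gives only a limit, > 10000 nM. Compound 2 `CN1CCC(C(=O)Nc2cccc(Nc3ncc(F)c(Nc4ccc(F)cc4)n3)c2)CC1` gives 1150 nM. Compound 3 `CN(C)c1ccc(C(=O)Nc2cccc(Nc3ncc(F)c(Nc4ccc(F)cc4)n3)c2)cc1` again gives only a limit, > 10000 nM. Two measured steps frame these three: an at least 8.6-fold lower number from compound 1 to compound 2 (0.93 log units; beyond the scatter) and an at least 8.6-fold higher number from compound 2 to compound 3 (0.93 log units; beyond the scatter), with the limit of > 10000 nM in this assay, at which 2 of the 3 values shown sit, marking where two of the values stop. Compound 4 `COCC(=O)Nc1cccc(Nc2ncc(F)c(Nc3ccc(F)cc3)n2)c1` changes compound 1 in one place: ((methoxymethyl)carbonyl)amino in place of (1,3-thiazol-2-yl)carbamoyl on an aromatic carbon. Among the compounds with values here, no measured step matches this exact change; compound 2 shows that a small non-aromatic group at this place can reach a measurable number, while compound 3 stays at the limit. Compound 4 is therefore expected to give 6000 nM, between 1500 nM and 20000 nM, an expected step of an at least 1.6-fold lower number from compound 1 to compound 4 (0.22 log units; that floor lies within the scatter).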

Compound 4, concentration for 50% growth inhibition: 4460 nM
Compound 4: the middle estimate sits 1.3-fold (0.13 log units) above what was measured; the measured number falls inside the stated range.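

With no ring in its new group, compound 4 still improves on the thiazole-bearing group, with an at least 2.2-fold lower number from compound 1 to compound 4 (0.35 log units; beyond the scatter), and methoxymethyl likewise improves on the aromatic 4-(dimethylamino)phenyl, with an at least 2.2-fold lower number from compound 3 to compound 4 (0.35 log units; beyond the scatter). A piperidine ring is therefore not required for a measurable number in this assay. It does give the better result of the two, as the change back to methoxymethyl shows a 3.9-fold higher number from compound 2 to compound 4 (0.59 log units; beyond the scatter).

On these data alone, the true sizes of the two steps from limits stay unknown: the limit of > 10000 nM in this assay, at which 2 of the 4 values shown sit. Whether an open-chain amine, such as dimethylaminomethyl, or a carboxylic acid would match compound 2 remains open.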